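Cyclopropyl to cyclohexyl on the alkene carbon

The compounds below may be only part of what the source reports. "The series", "measured", "known", "first", "only" and "open" are said of these compounds alone.

For the measured compounds named here, compound 2 `O=C(O)/C=C/c1ccc(/C(=C(\c2ccccc2)C2CC2)c2ccc3[nH]ncc3c2)cc1` gives 13 nM in a functional assay on MCF7 cells (Homo sapiens) for cytotoxicity, read by CellTiter-Glo, with a stated time of 5 days (on this read-out higher numbers stand for weaker inhibition and lower numbers for stronger inhibition), and this is the only number so far. Compound 1 `O=C(O)/C=C/c1ccc(/C(=C(/CCO)c2ccccc2)c2ccc3[nH]ncc3c2)cc1` returns only a limit in this assay, > 1000 nM, which is the limit of > 1000 nM in this assay, at which 1 of the 2 values shown sits. Going by the values given here, the single measured step runs an at least 76-fold lower number from compound 1 to compound 2 (1.88 log units; beyond the scatter), from a limit to the one number, so its true size is unknown beyond the bound given.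

Compound 3 `O=C(O)/C=C/c1ccc(/C(=C(\c2ccccc2)C2CCCCC2)c2ccc3[nH]ncc3c2)cc1` differs from compound 2 by cyclohexyl in place of cyclopropyl on a double-bonded chain carbon bound to an aromatic carbon and a double-bonded chain carbon. Among the compounds with values here, the one step on record concerns the same position but exchanges an open chain for a ring, not one ring for another, so it bears on this change only as a sign that the site tolerates a change of group. In this assay compound 3 is therefore expected to stay near compound 2, with a change estimated at a 3.1-fold higher number from compound 2 to compound 3 (0.49 log units; beyond the scatter). The estimate for compound 3 in this assay is 40 nM, between 10 nM and 250 nM.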

Compound 3, half-maximal inhibitory concentration: 64 nM
For compound 3 the middle estimate is 1.6-fold (0.20 log units) below the measured one, and the stated range covers the measured number.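

In this assay the ring on the double-bonded chain carbon is not interchangeable, and enlarging it carries a cost: a 4.9-fold higher number from compound 2 to compound 3 (0.69 log units; beyond the scatter). Cyclohexyl nevertheless keeps a wide margin over the 2-hydroxyethyl group: an at least 15-fold lower number from compound 1 to compound 3 (1.19 log units; beyond the scatter). That margin is only a bound, since compound 1 gives a limit and not a number: the limit of > 1000 nM in this assay, at which 1 of the 3 values shown sits.

Two rings cannot show whether the number rises steadily with ring size, and cyclobutyl or cyclopentyl at this position would test that. On these data alone, it also remains open whether the weak result of compound 1 goes with its hydroxyl group or with the open chain itself, a question that a plain propyl chain would address.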